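The source may report more compounds than this note shows. Statements on the series, on what has been measured and on what is new or still open speak of the compounds shown alone.

Of the compounds shown here, three that share one core have been measured in an ADME assay on 184B5 cells (Homo sapiens) for cytotoxicity, read by MTT assay, with a stated time of 72 h; a higher number here means a weaker inhibitor of growth, a lower number a stronger inhibitor of growth. Compound 1 `CCCCC[Se]c1nc([Se]CCCCC)c2cccnc2n1` carries a pentyl on each of its selenium atoms. In this assay compound 1 gives > 100000 nM, which is a limit of the assay and not a number. Compound 2 `Nc1nc([SeH])nc2ncccc12` has an amino group and a free selenol, and in this assay compound 2 gives 31100 nM. Compound 3 `[SeH]c1nc([SeH])c2cccnc2n1` has two free selenols, and in this assay compound 3 gives 8260 nM. Of the two numbers, compound 2 stands highest; the step of a 3.8-fold lower number from compound 2 to compound 3 (0.58 log units; beyond the scatter) is modest but beyond the scatter.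

Compound 4 `CCCCC[Se]c1nc(N)c2cccnc2n1` differs from compound 2 by pentyl in place of hydrogen on a selenium. For the measured compounds named here, no measured step changes a substituent on selenium alone, so none bears on this change directly. The values do show that compound 1, with pentyl on both selenium atoms, sits at the limit of > 100000 nM in this assay, at which 1 of the 3 values shown sits. Compound 3, with neither pentyl, gives a number well inside the measurable range. Compound 4 carries one such pentyl, so in this assay compound 4 is expected to give a higher number than its parent. The expected step is therefore a 1.9-fold higher number from compound 2 to compound 4 (0.29 log units; within the scatter), toward weaker inhibition. The estimate for compound 4 is 60000 nM, within a range from 20000 nM to 180000 nM, with a fair chance that this assay reports only a limit.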

Compound 4, concentration for total growth inhibition: 40200 nM
Estimate against measurement, compound 4: 1.5-fold (0.17 log units) above, within the range that was stated.
By their numbers in this assay, from the lowest: compound 3; then compounds 2 and 4 (each within the scatter of the next). At a limit, above all of these: compound 1.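

In this assay, pentyl in place of hydrogen on a selenium gives a 1.3-fold higher number from compound 2 to compound 4 (0.11 log units; within the scatter), so with the amino group in place on the shared core, the free selenol and its pentyl form cannot be told apart on this measure. A single pentyl on a selenium whose other neighbour is an aromatic carbon is therefore not enough to take a compound to the limit of the assay, whereas exchanging the second pentyl-bearing selenium of compound 1 for the nitrogen of the amino group gives an at least 2.4-fold lower number from compound 1 to compound 4 (0.39 log units; beyond the scatter), a change that lies beyond the scatter even though one end of it is not a true number. Compound 1 stands as a limit and not as a number: the limit of > 100000 nM in this assay, at which 1 of the 4 values shown sits.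

What the compounds shown leave open is whether a shorter chain such as methyl, a longer chain such as octyl, or a benzyl group on the same selenium would read as pentyl does. They also leave open how a single pentyl would read on compound 3, where a second selenol takes the place of the amino group.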